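The source may hold more compounds than are shown below. What is called first, only, known or untested is meant among the compounds shown, and "the series" means these compounds.

Measured compounds:
compound 1 `Cc1cccc2nc(-c3cccc(NC(=O)CCCc4ccccc4)c3)[nH]c12` gives 38600 nM
compound 2 `O=C(CCCc1ccccc1)Nc1cccc(-c2nc3ccccc3[nH]2)c1` gives 43000 nM
compound 3 `O=[N+]([O-])c1ccc(-c2nc3ccccc3o2)cc1` gives 36000 nM

All three were tested in an assay on cells for inhibition of matrix metalloproteinase-9 (Homo sapiens), read by fluorescence, with stated times of 15 min and 4 h; on this read-out lower numbers stand for stronger inhibition and higher numbers for weaker inhibition. Compound 2 and compound 1 share a core and differ in one place, (methyl in place of hydrogen on an aromatic carbon). The step that this change made is a 1.1-fold lower number from compound 2 to compound 1 (0.05 log units; within the scatter). Compound 3 rests on a different core; the difference between the two cores is not broken down here. In this assay compound 3 gives 36000 nM, and the three measured numbers all lie within the scatter of one another, so no order among them can be read.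

Compound 4, `Cc1ccc2oc(-c3ccc([N+](=O)[O-])cc3)nc2c1`, has not yet been measured. It differs from compound 3 by methyl in place of hydrogen on an aromatic carbon. Among the measured compounds shown here, this is the same kind of change as the one from compound 2 to compound 1, though not the same: in compound 1 the methyl sits ortho to a fused ring and meta to a fused ring, whereas in compound 4 it sits meta to a fused ring and para to a fused ring. Because a 1.1-fold lower number from compound 2 to compound 1 (0.05 log units; within the scatter) stayed within the scatter, the corresponding step here is expected to be small as well, a 1.1-fold lower number from compound 3 to compound 4 (0.02 log units; within the scatter). On that basis compound 4 is estimated to give 34000 nM in this assay, expected to fall between 15000 nM and 75000 nM. For the measured compounds named here, the only support is one step on another core, so the expectation is loose.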

Compound 4, half-maximal inhibitory concentration: 14900 nM
Estimate against measurement, compound 4: 2.3-fold (0.36 log units) above; the whole stated range lies above it.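

In this assay, methyl in place of hydrogen on an aromatic carbon gave a 2.4-fold lower number from compound 3 to compound 4 (0.38 log units; beyond the scatter), a modest step, while on the other core the same kind of change gave a 1.1-fold lower number from compound 2 to compound 1 (0.05 log units; within the scatter). Set side by side, the two steps cannot be told apart: the same change on two cores in this assay, a 1.1-fold lower number (0.05 log units; within the scatter) from compound 2 to compound 1 and a 2.4-fold lower number (0.38 log units; beyond the scatter) from compound 3 to compound 4, 2.2-fold (0.34 log units) apart, within the scatter of two such steps. Among the compounds shown here, the change can therefore be carried between these two cores with no measurable difference in its step, but this does not show that the step is the same on both, since there is only one pair on each core, the methyl stands in a different place on each, and only the step on the core of compound 3 lies beyond the scatter.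

The compounds shown leave open whether an ethyl or a methoxy group at the place of the methyl in compound 4 would move the number further, and whether a second methyl elsewhere on that ring would add to the step. They also leave open what an amine or a carboxylic acid in place of the nitro group of compound 4 would do, and how a shorter chain in place of the phenyl-ended chain of compound 1 would read in this assay.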